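Adding a nitro group to compound 1

This account rests on a few compounds, and the source may have more. Where it says the series, first, only, none or still open, it means among the compounds named here.

Compound 1 `Cc1ncc([N+](=O)[O-])n1CCSc1nnc(-c2ccccc2)o1` gives 30100 nM
Compound 2 `Cc1ccccc1-c1nnc(SCCn2c([N+](=O)[O-])cnc2C)o1` gives 32300 nM
Compound 3 `CCOc1ccccc1-c1nnc(SCCn2c([N+](=O)[O-])cnc2C)o1` gives 30300 nM

All three values come from a functional assay on SGC-7901 cells (Homo sapiens) for cytotoxicity, read by MTT assay, with a stated time of 48 h (a lower number here means a stronger inhibitor, a higher number a weaker inhibitor), and lie within the scatter of one another. Compound 1 at 30100 nM therefore stands level with the other two, neither ahead of them nor behind them.

Compound 4 `Cc1ncc([N+](=O)[O-])n1CCSc1nnc(-c2ccc([N+](=O)[O-])cc2)o1` has not yet been measured. It keeps the core of compound 1 and differs in one place (nitro in place of hydrogen on an aromatic carbon), with nitro in place of hydrogen on an aromatic carbon, para to a large group.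

Two measured steps made a similar swap of hydrogen on an aromatic carbon. With methyl the result was a 1.1-fold higher number from compound 1 to compound 2 (0.03 log units; within the scatter) and with ethoxy it was a 1.0-fold higher number from compound 1 to compound 3 (0.00 log units; within the scatter) in each case a small change. Going between those two groups gave a 1.1-fold lower number from compound 2 to compound 3 (0.03 log units; within the scatter) and this was just as small. Neither step brought in a nitro, so they guide the expectation only loosely and the range has to stay wide.

In this assay no step beyond the scatter is expected, and the estimated 1.1-fold lower number from compound 1 to compound 4 (0.03 log units; within the scatter) has no clear direction. Compound 4 is estimated at 28000 nM (range 12000 nM to 55000 nM).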

Compound 4, half-maximal inhibitory concentration: 12200 nM
The estimate for compound 4 lay 2.3-fold (0.36 log units) above the measured number; the measured number falls inside the stated range.
By their numbers in this assay, from the lowest: compound 4; then compounds 1, 3 and 2 (each within the scatter of the next).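

In this assay, nitro in place of hydrogen on the six-membered aromatic ring, para to a large group, gives a 2.5-fold lower number from compound 1 to compound 4 (0.39 log units; beyond the scatter), and this is the first step among these compounds to go beyond the scatter. The earlier swaps on that ring, methyl with a 1.1-fold higher number from compound 1 to compound 2 (0.03 log units; within the scatter) and ethoxy with a 1.0-fold higher number from compound 1 to compound 3 (0.00 log units; within the scatter), made it look as if changes there hardly mattered, but compound 4 shows that the number can respond to a change on this ring, although the step is only modest. No measurement here bears on what lies behind this step.

Within the data shown here, with only one nitro compound in view, it remains open whether the lower number belongs to nitro itself or would also appear with another group at the same place, such as a nitrile, a trifluoromethyl group, an amine or a carboxylic acid. Going by these compounds, it is also open whether nitro on a different carbon of that ring would give a step of similar size, and whether a second group added to the ring of compound 4 would take the number lower still.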